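Moving the Substituent on the Pendant Phenyl Ring

The source may hold more compounds than are shown below. What is called first, only, known or untested is meant among the compounds shown, and "the series" means these compounds.

Three ureas built on one shared core have been tested in an assay on microsomes for inhibition of acyl-CoA:cholesterol acyltransferase (Oryctolagus cuniculus); on this read-out higher numbers stand for weaker inhibition and lower numbers for stronger inhibition. Compound 1 `COc1cccc(C2(CNC(=O)Nc3c(C(C)C)cccc3C(C)C)CCCC2)c1` gives 13 nM. Compound 2 `COc1ccc(C2(CNC(=O)Nc3c(C(C)C)cccc3C(C)C)CCCC2)cc1` gives 31 nM, the second highest of the three numbers, nearest to compound 3 and furthest from compound 1. Compound 3 `CC(C)c1cccc(C(C)C)c1NC(=O)NCC1(c2ccc(OCc3ccccc3)cc2)CCCC1` gives 34 nM. The step of a 2.4-fold higher number from compound 1 to compound 2 (0.38 log units; beyond the scatter) is modest but beyond the scatter, whereas the step of a 1.1-fold higher number from compound 2 to compound 3 (0.04 log units; within the scatter) is within it.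

Compound 4 `CC(C)c1cccc(C(C)C)c1NC(=O)NCC1(c2cccc(N(C)C)c2)CCCC1` has not yet been measured. It differs from compound 2 in one place: 3-(dimethylamino)phenyl in place of 4-methoxyphenyl on a saturated ring carbon. For the measured compounds named here, two measured steps bear on this change. The first shows that a methoxy group gave a lower number as 3-methoxyphenyl than as 4-methoxyphenyl. The second shows that enlarging the group on the oxygen of 4-methoxyphenyl left the number unchanged within the scatter. Going by the values given here, no measured compound carries a dimethylamino group, so the effect of that part of the change is unknown. A return toward the number of compound 1 is expected because of the step of a 2.4-fold higher number from compound 1 to compound 2 (0.38 log units; beyond the scatter). The step expected in this assay is a 1.7-fold lower number from compound 2 to compound 4 (0.24 log units; within the scatter). Compound 4 is therefore estimated at 18 nM, with a range from 6 nM to 60 nM.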

Compound 4, half-maximal inhibitory concentration: 33 nM
Compound 4: middle estimate off by 1.8-fold (0.26 log units), on the low side; low and high end bracket the measured number.
By their numbers in this assay, from the lowest: compound 1; then compounds 2, 4 and 3 (each within the scatter of the next).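

In this assay, exchanging methoxy for dimethylamino on an aromatic carbon, with nothing else altered, gives a 2.5-fold higher number from compound 1 to compound 4 (0.40 log units; beyond the scatter) and so shows that the lower number of compound 1 depends on the methoxy group itself, not only on where a substituent sits on the pendant phenyl ring. The exchange of 4-methoxyphenyl for 3-(dimethylamino)phenyl gives a 1.1-fold higher number from compound 2 to compound 4 (0.03 log units; within the scatter) and so changes both the group and its place on the ring without a readable shift; this single step cannot tell whether neither change matters here or whether the two offset each other. No measurement available here explains the difference between the methoxy and dimethylamino compounds.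

The compounds shown leave open whether 4-(dimethylamino)phenyl would match 3-(dimethylamino)phenyl in this assay, which would separate the effect of the group from the effect of its place on the ring. They also leave open how other groups on that ring, such as a hydroxyl, an ethoxy group or a primary amine, would compare with methoxy and dimethylamino.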